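The compounds below may be only part of what the source reports. "The series", "measured", "known", "first", "only" and "open" are said of these compounds alone.

Compound 1 `Cn1cncc1CN1CC(N(CC2CCN(C(=O)C3CCCC3)CC2)S(=O)(=O)c2ccccn2)Cc2cc(C#N)ccc21`: 0.5 10^-6 cm/s
Compound 2 `Cn1cncc1CN1CC(N(CC2CCN(C(=O)CC(C)(C)C)CC2)S(=O)(=O)c2ccccn2)Cc2cc(C#N)ccc21`: 0.5 10^-6 cm/s
Compound 3 `Cn1cncc1CN1CC(N(Cc2cccc(-n3cccc3)c2)S(=O)(=O)c2ccccn2)Cc2cc(C#N)ccc21`: 2.3 10^-6 cm/s

In an ADME assay on Caco-2 cells (Homo sapiens) for permeability, in the apical to basolateral direction (a lower number here means that the compound crosses the layer more slowly, a higher number that the compound crosses the layer faster), compound 2 gives 0.5 10^-6 cm/s, level with compound 1 and together with it the lowest of the three numbers, while compound 3 stands furthest off at 2.3 10^-6 cm/s. Compound 4 `Cn1cncc1CN1CC(N(CC2CCN(C(=O)NC(C)(C)C)CC2)S(=O)(=O)c2ccccn2)Cc2cc(C#N)ccc21` carries (tert-butyl)amino in place of neopentyl on a carbonyl carbon. For the measured compounds named here, the only measured step at this carbonyl is no change at the digits printed from compound 1 to compound 2 (within the scatter). Going by the values given here, no measured step puts an amino group there, and compound 3 lacks this carbonyl, so the evidence is thin. On that single step, the expected change in this assay is no change at the digits printed from compound 2 to compound 4 (within the scatter), none beyond the scatter. For compound 4 the estimate is 0.5 10^-6 cm/s, with an expected range of 0.2 10^-6 cm/s to 1 10^-6 cm/s.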

Compound 4, apparent permeability: 0.6 10^-6 cm/s
Compound 4: the middle estimate sits 1.2-fold (0.08 log units) below what was measured; the measured number falls inside the stated range.
By their numbers in this assay, from the lowest: compounds 1, 2 and 4 (each within the scatter of the next); then compound 3.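

In this assay, (tert-butyl)amino on this carbonyl carbon brings a nitrogen and a hydrogen-bond donor into the place, and the step of a 1.2-fold higher number from compound 2 to compound 4 (0.08 log units; within the scatter) shows that the swap from neopentyl leaves the reading flat. The cyclopentyl comparison agrees, with a 1.2-fold higher number from compound 1 to compound 4 (0.08 log units; within the scatter) for that replacement. No evidence at hand explains this flat reading.

Still open, from the compounds shown here alone, is whether a carboxylic acid or a longer chain on this carbonyl would move the number beyond the scatter. Compound 3 lacks this carbonyl, so it cannot settle that.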